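Swapping Methoxyphenyl for Bromofluorophenyl on a Shared Core

This account rests on a few compounds, and the source may have more. Where it says the series, first, only, none or still open, it means among the compounds named here.

Compound 1 `O=C(Nc1ccc(Oc2ccnc3[nH]ccc23)c(F)c1)c1cc2cccnc2n(-c2ccc(F)cc2)c1=O` and compound 2 `COc1ccc(-n2c(=O)c(C(=O)Nc3ccc(Oc4ccnc5[nH]ccc45)c(F)c3)cc3cccnc32)cc1` share one core and differ in a single group. Going by the values given here, in a functional assay on HT-29 cells (Homo sapiens) for antiproliferative activity, read by MTT assay, with a stated time of 72 h (on this read-out lower numbers stand for stronger inhibition and higher numbers for weaker inhibition), compound 1 gives 36 nM, while compound 2 gives 540 nM, the highest of the two numbers measured so far, and the step is a 15-fold higher number from compound 1 to compound 2 (1.18 log units; beyond the scatter). Compound 3 `O=C(Nc1ccc(Oc2ccnc3[nH]ccc23)c(F)c1)c1cc2cccnc2n(-c2ccc(Br)cc2F)c1=O` carries 4-bromo-2-fluorophenyl in place of 4-methoxyphenyl on an aromatic nitrogen. Among the compounds with values here, only that one step bears on this change; it was large, and the entering group, like the fluoro group of compound 1, holds halogen and no oxygen. The number for compound 3 is expected to fall by a 9.0-fold lower number from compound 2 to compound 3 (0.95 log units; beyond the scatter), to an estimated 60 nM within 15 nM to 300 nM.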

Compound 3, half-maximal inhibitory concentration: 820 nM
Compound 3: the middle estimate sits 14-fold (1.14 log units) below what was measured; measured number outside the range, above it.
By their numbers in this assay, from the lowest: compound 1; then compounds 2 and 3 (each within the scatter of the next).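

Holding halogen and no oxygen is therefore not enough at this position: in this assay, exchanging 4-fluorophenyl for 4-bromo-2-fluorophenyl gives a 23-fold higher number from compound 1 to compound 3 (1.36 log units; beyond the scatter), while exchanging 4-methoxyphenyl for 4-bromo-2-fluorophenyl gives a 1.5-fold higher number from compound 2 to compound 3 (0.18 log units; within the scatter). Of the three groups on this aromatic nitrogen, only the 4-fluorophenyl of compound 1 goes with the lower number. No measurement here accounts for this difference.
The compounds shown leave open whether the bromine or the added fluorine goes with the higher number of compound 3, since both differ from compound 1 at once. As far as these compounds go, how an amine or a carboxylic acid on this phenyl ring would read also remains open.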